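The source may hold more compounds than are shown below. What is called first, only, known or untested is meant among the compounds shown, and "the series" means these compounds.

Working notes on the series.

Compound 1 `C[C@H](Nc1ncnc(N)c1C#N)c1nc2ccc(F)cc2c(C(N)=O)c1-c1ccccc1` is the reference point here: in an assay on Sf9 cells for inhibition of phosphatidylinositol 4,5-bisphosphate 3-kinase catalytic subunit beta isoform (Homo sapiens), with a stated time of 20 min (on this read-out higher numbers stand for weaker inhibition and lower numbers for stronger inhibition), compound 1 gives 3540 nM. Compound 2 `CCNC(=O)c1c(-c2ccccc2)c([C@H](C)Nc2ncnc(N)c2C#N)nc2ccc(F)cc12` carries an ethyl on the amide-type nitrogen where compound 1 carries a hydrogen, and in this assay compound 2 gives 17000 nM. Within the data shown here, that single change is the only measured step in the set, a 4.8-fold higher number from compound 1 to compound 2 (0.68 log units; beyond the scatter), so compound 2 stands at the higher of the two numbers, with compound 1 as its only neighbour.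

Compound 3 `CC(C)NC(=O)c1c(-c2ccccc2)c([C@H](C)Nc2ncnc(N)c2C#N)nc2ccc(F)cc12` takes the same direction one bond further out: methyl in place of hydrogen on a saturated chain carbon bound to an amide-type nitrogen and a saturated chain carbon. Among the measured compounds shown here, the only step that bears on it is the one from compound 1 to compound 2, in which enlarging the amide substituent from hydrogen to ethyl raised the number modestly. Going from ethyl to isopropyl is a smaller addition, so a small further rise in this assay is expected, near or only just beyond the scatter, with no ground in the data for a reversal. For compound 3 the expected value in this assay is 28000 nM, within a range of 11000 nM to 70000 nM. The step this estimate implies is a 1.6-fold higher number from compound 2 to compound 3 (0.22 log units; within the scatter).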

Compound 3, half-maximal inhibitory concentration: 8050 nM
For compound 3 the middle estimate is 3.5-fold (0.54 log units) above the measured one, and the stated range ends above it.
By their numbers in this assay, from the lowest: compound 1; then compound 3; then compound 2.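

In this assay, the amide substituent does not follow a simple order of size: changing ethyl to isopropyl gives a 2.1-fold lower number from compound 2 to compound 3 (0.32 log units; beyond the scatter) while isopropyl in place of the amide hydrogen still gives a 2.3-fold higher number from compound 1 to compound 3 (0.36 log units; beyond the scatter) in the opposite direction. Both substituents on the amide nitrogen therefore leave the number above that of the unsubstituted amide, but the methyl added on the saturated chain carbon recovers part of the loss seen with ethyl, so the number does not climb steadily as carbon is added at this position. No measurement given here accounts for the branched group lying below the ethyl group.

Going by these compounds, it remains open whether a methyl alone on the amide nitrogen, a longer chain such as butyl, or a cyclopropyl group would fall nearer to ethyl or to isopropyl. Also open, on these data alone, is whether a carboxylic acid or a methyl ester in place of the primary amide would keep the number of compound 1 or move it further in either direction.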